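Amino for Hydroxy on the Shared Core

The source may hold more compounds than are shown below. What is called first, only, known or untested is meant among the compounds shown, and "the series" means these compounds.

The measured compounds:
compound 1, `Oc1cccc2c1CCCC2c1c[nH]cn1` — 30.9 nM
compound 2, `CCS(=O)(=O)Nc1cccc2c1CCCC2c1c[nH]c(C)n1` — < 10000 nM (a limit of the assay, not a number)
compound 3, `CS(=O)(=O)Nc1cccc2c1CCCC2C1=NCCN1` — 4270 nM

In an assay on isolated protein for binding affinity to Alpha-1D adrenergic receptor (Rattus norvegicus), read by radioligand binding (on this read-out higher numbers stand for weaker inhibition and lower numbers for stronger inhibition), compound 1 gives 30.9 nM, the lowest of the two numbers available. The nearest is compound 3, which in this assay gives 4270 nM, a gap beyond the scatter. Compound 2 only reaches (the limit of < 10000 nM in this assay, at which 1 of the 3 values shown sits). Where the hydroxy of compound 1 is replaced, the two replaced sulfonamide compounds both stand far weaker, though each also differs from compound 1 elsewhere, so no single step among the measured compounds is defined.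

Compound 4, `Nc1cccc2c1CCCC2c1c[nH]cn1`, keeps the core of compound 1 and differs only in one place: amino in place of hydroxy on an aromatic carbon. Both groups are counted as one heavy atom carrying one donor and one acceptor, so the change is the smallest shown here. In this assay the expected step is a 3.9-fold higher number from compound 1 to compound 4 (0.59 log units; beyond the scatter), a shift toward higher numbers of a size close to the scatter, since the much weaker compounds 2 and 3 carry larger groups and other changes. Compound 4 is therefore estimated at 120 nM, with a range from 25 nM to 700 nM.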

Compound 4, inhibition constant: 191 nM
The estimate for compound 4 lay 1.6-fold (0.20 log units) below the measured number; the range from low to high includes it.
By their numbers in this assay, from the lowest: compound 1; then compound 4; then compound 3.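

In this assay, within the data shown here, amino in place of hydroxy on an aromatic carbon gives a 6.2-fold higher number from compound 1 to compound 4 (0.79 log units; beyond the scatter), and this is the first step on the shared core that can be read at a single place. The earlier compounds shown here could not show this, since each of them differs from compound 1 in more than one place; the step now shows that this position, ortho to a fused ring and meta to a fused ring, responds to an exchange of oxygen for nitrogen even though the counts of heavy atoms, donors and acceptors and the net charge stay the same. Nothing among the measurements shown gives a reason for the size of this step.

Compound 2 and compound 3 each differ from compound 4 in more than one place, so the steps that would separate the sulfonamide from its other changes cannot be read. From the compounds shown here alone, how the position would respond to a methoxy group, a fluorine or a methylamino group in place of the hydroxy also stays open, as does whether the step holds on a core with another ring in place of the imidazole.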